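Nitrophenyl Variant of a Triazole Thioether Series

The source may report more compounds than this note shows. Statements on the series, on what has been measured and on what is new or still open speak of the compounds shown alone.

compound 1 `Clc1ccccc1CSc1nnc(-c2ccncc2)n1-c1ccccc1` — 13900 nM
compound 2 `Brc1ccc(CSc2nnc(-c3ccncc3)n2-c2ccccc2)cc1` — 11100 nM

In a functional assay on HCT-116 cells (Homo sapiens) for inhibition, read by MTT assay, with a stated time of 48 h (on this read-out higher numbers stand for weaker inhibition and lower numbers for stronger inhibition), compound 1 gives 13900 nM and compound 2 gives 11100 nM. These two numbers lie within the scatter of each other, as the step of a 1.3-fold lower number from compound 1 to compound 2 (0.10 log units; within the scatter) shows, so compound 2 stands level with compound 1 rather than apart from it. Compound 3 `O=[N+]([O-])c1cccc(CSc2nnc(-c3ccncc3)n2-c2ccccc2)c1` differs from compound 2 by 3-nitrophenyl in place of 4-bromophenyl on a saturated chain carbon bound to a sulfur. Going by the values given here, only that one measured step, an exchange of one aryl group for another on the same chain carbon, bears on this change, and it stayed within the scatter, so no step beyond the scatter is expected in this assay. Compound 3 is therefore expected to give 11500 nM, with a range from 5000 nM to 26000 nM. This amounts to an expected step of a 1.0-fold higher number from compound 2 to compound 3 (0.02 log units; within the scatter).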

Compound 3, half-maximal inhibitory concentration: 19800 nM
The estimate for compound 3 lay 1.7-fold (0.24 log units) below the measured number; low and high end bracket the measured number.
By their numbers in this assay, from the lowest: compounds 2, 1 and 3 (each within the scatter of the next).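

In this assay, going by these compounds alone, 3-nitrophenyl is the first group on the saturated chain carbon bound to a sulfur to bring hydrogen-bond acceptors, yet the steps of a 1.8-fold higher number from compound 2 to compound 3 (0.25 log units; within the scatter) and a 1.4-fold higher number from compound 1 to compound 3 (0.15 log units; within the scatter) both stay within the scatter. The three aryl groups at this place, 2-chlorophenyl, 4-bromophenyl and 3-nitrophenyl, therefore stand level with one another. The compounds shown leave open whether an amine or a carboxylic acid on this aryl ring, or a longer chain at this place, would give a step beyond the scatter. No supporting data at hand speak to the reason for this level standing.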